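The compounds below may be only part of what the source reports. "The series", "measured", "known", "first", "only" and "open" are said of these compounds alone.

Compound 1 `Cc1nc(-c2ccccc2)sc1C(=O)CSc1nc(-c2ccc(Cl)c(Cl)c2)c(C#N)c(=O)[nH]1` and compound 2 `Cc1nc(-c2ccccc2)sc1C(=O)CSc1nc(-c2ccccc2)c(C#N)c(=O)[nH]1` share one core, and in a functional assay on U-87MG ATCC cells for antiproliferative activity against U-87 MG (Homo sapiens), read by MTT assay, with a stated time of 48 h, tested at 100 uM (a lower number here means a stronger effect, a higher number a weaker effect of the compound at the concentration tested), compound 1 gives 24.4% while compound 2 gives 9.23%. The change between them, (phenyl in place of 3,4-dichlorophenyl on an aromatic carbon), made the step of a number 15.2 percentage points lower from compound 1 to compound 2 (beyond the scatter). Compound 3 `COc1ccc(-c2nc(C)c(C(=O)CSc3nc(-c4ccc(Cl)c(Cl)c4)c(C#N)c(=O)[nH]3)s2)cc1` differs from compound 1 by methoxy in place of hydrogen on an aromatic carbon, and in this assay compound 3 gives 31.1%, a step of a number 6.7 percentage points higher from compound 1 to compound 3 (within the scatter). Compound 4 `COc1ccc(-c2nc(C)c(C(=O)CSc3nc(-c4ccccc4)c(C#N)c(=O)[nH]3)s2)cc1` has not been measured; it differs from compound 3 by phenyl in place of 3,4-dichlorophenyl on an aromatic carbon, the same change as from compound 1 to compound 2, at a place described in identical words. The step from compound 3 to compound 4 is therefore expected to be about a number 15.1 percentage points lower from compound 3 to compound 4 (beyond the scatter) in this assay, resting on the step of a number 15.2 percentage points lower from compound 1 to compound 2 (beyond the scatter) and on the value of compound 3, 31.1%. Compound 4 is accordingly estimated at 16%, between 6% and 28%.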

Compound 4, a percentage reported as activity, at one concentration (the size of the read-out at that concentration, not a potency): 10.9%
For compound 4 the middle estimate is 5.1 percentage points above the measured one; measured number inside the range.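

In this assay, phenyl in place of 3,4-dichlorophenyl gave a number 20.2 percentage points lower from compound 3 to compound 4 (beyond the scatter), and the change carried over between the two cores with no difference beyond the scatter: the same change on two cores in this assay, a number 15.2 percentage points lower (beyond the scatter) from compound 1 to compound 2 and a number 20.2 percentage points lower (beyond the scatter) from compound 3 to compound 4, 5 percentage points apart, within the scatter of two such steps. The methoxy change also behaved alike in both settings, giving a number 1.7 percentage points higher from compound 2 to compound 4 (within the scatter): the same change on two cores in this assay, a number 6.7 percentage points higher (within the scatter) from compound 1 to compound 3 and a number 1.7 percentage points higher (within the scatter) from compound 2 to compound 4, 5 percentage points apart, within the scatter of two such steps. Among these compounds, this shows agreement across only two pairs at one tested concentration; it does not show that either change would carry to other cores, and it gives no potency.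

The compounds shown leave open whether a phenyl bearing a single chlorine would fall in line with these steps. They also leave open what an amine or a carboxylic acid on that phenyl, or a longer chain in place of the methoxy group, would do.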